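Two Chlorophenyl Isomers on Two Related Cores

The source may report more compounds than this note shows. Statements on the series, on what has been measured and on what is new or still open speak of the compounds shown alone.

Of the compounds shown here, three have been measured in a functional assay on A549 cells (Homo sapiens) for antiproliferative activity, read by MTT assay, with a stated time of 24 h; on this read-out lower numbers stand for stronger inhibition and higher numbers for weaker inhibition. Compound 1 `O=C(NNc1ccccc1Cl)c1ccc(NS(=O)(=O)c2cnc(O)nc2O)cc1` gives 3340 nM in this assay. Compound 2 `O=C(NNc1cccc(Cl)c1)c1ccc(NS(=O)(=O)c2cnc(O)nc2O)cc1` differs from compound 1 only by 3-chlorophenyl in place of 2-chlorophenyl on an amine nitrogen, and in this assay compound 2 gives 7290 nM; the step of a 2.2-fold higher number from compound 1 to compound 2 (0.34 log units; beyond the scatter). Compound 3 `O=C(NNc1ccccc1Cl)c1ccccc1NS(=O)(=O)c1cnc(O)nc1O` carries the same 2-chlorophenyl group as compound 1 but on a differently joined core; the difference between the two cores is not broken down here. In this assay compound 3 gives 5480 nM, a number that lies within the scatter of both compound 2 and compound 1.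

Compound 4 `O=C(NNc1cccc(Cl)c1)c1ccccc1NS(=O)(=O)c1cnc(O)nc1O` has not yet been measured. It differs from compound 3 by 3-chlorophenyl in place of 2-chlorophenyl on an amine nitrogen, the same change, at the same place, as that made from compound 1 to compound 2. Whether the step carries over unchanged to the core of compound 3 is not known from these data. The step expected for compound 4 is a 2.0-fold higher number from compound 3 to compound 4 (0.30 log units; within the scatter), because a 2.2-fold higher number from compound 1 to compound 2 (0.34 log units; beyond the scatter) came from the same change at the same place. In this assay compound 4 is expected to give 11000 nM, estimated to fall between 5500 nM and 25000 nM.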

Compound 4, half-maximal inhibitory concentration: 5290 nM
Compound 4: the middle estimate sits 2.1-fold (0.32 log units) above what was measured; measured number outside the range, below it.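

In this assay, among the compounds shown here, 3-chlorophenyl in place of 2-chlorophenyl on an amine nitrogen gives a 1.0-fold lower number from compound 3 to compound 4 (0.02 log units; within the scatter), so on the core of compound 3 the change leaves no step that can be told from the scatter, unlike on the core of compound 1. Set side by side, however, the two steps cannot themselves be told apart: the same change on two cores in this assay, a 2.2-fold higher number (0.34 log units; beyond the scatter) from compound 1 to compound 2 and a 1.0-fold lower number (0.02 log units; within the scatter) from compound 3 to compound 4, 2.3-fold (0.35 log units) apart, within the scatter of two such steps. For the compounds shown here, this shows that the step seen on the core of compound 1 cannot be relied on to reappear on the core of compound 3, but it does not show that the core alters the effect of the change, since each core offers only one pair and the two results remain compatible with a single small effect.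

The compounds shown leave open how an unsubstituted phenyl, a bromophenyl or a methoxyphenyl on the same amine nitrogen would read on either core. They also leave open whether any such change would give steps large enough to separate the two cores clearly.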